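Chloro removal on the benzamide of compound 2

The source may report more compounds than this note shows. Statements on the series, on what has been measured and on what is new or still open speak of the compounds shown alone.

Measured so far in a physicochemical assay for lipophilicity; a lower number here means a more polar compound, a higher number a more lipophilic compound:
Compound 1, `Cc1cc(=O)[nH]c2cc(NC(=O)c3cccc4ccccc34)ccc12`: 1.72
Compound 2, `Cc1cc(=O)[nH]c2cc(NC(=O)c3ccc(Cl)cc3Cl)ccc12`: 1.83
Compound 3, `Cc1cc(=O)[nH]c2cc(NC(=O)/C=C/c3ccccc3)ccc12`: 1.69

Three amides on the shared core have numbers in this assay. Compound 2 has the highest of the three; the nearest to it is compound 1, lower by a gap within the scatter, and the furthest is compound 3, lower by a gap that is also within the scatter. No order among the three is therefore claimed from these numbers.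

Compound 4, `Cc1cc(=O)[nH]c2cc(NC(=O)c3ccccc3Cl)ccc12`, is not yet measured. Against compound 2 the counted difference is hydrogen in place of chloro on an aromatic carbon. Among the measured compounds shown here, no step between measured compounds matches this change, so nothing measured calibrates it; the expectation rests on the change alone, a chloro group of one heavy atom leaving and a hydrogen entering on an aromatic carbon. In this assay a step downward from compound 2, beyond the scatter, is expected, of the size a number 0.53 log units lower from compound 2 to compound 4 (beyond the scatter). Compound 4 is accordingly expected to give 1.3, with a range of 1 to 1.6. The measurement will show whether compound 4 settles at the lower end of the series.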

Compound 4, partition coefficient: 1.55
Beside the measured number, compound 4's estimate is 0.25 log units below it; the measured number falls inside the stated range.
By their numbers in this assay, from the lowest: compounds 4, 3, 1 and 2 (each within the scatter of the next).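

In this assay, hydrogen in place of chloro on an aromatic carbon, at the place meta to a chloro group and para to a large group, gives a number 0.28 log units lower from compound 2 to compound 4 (within the scatter). Among the compounds shown here, this is the first step between two compounds that differ in one place, and it shows that, at this position and with the other chloro group kept, this single exchange stays within the scatter. All the amides shown on the shared core thus remain without a claimed order, and no measured evidence on hand bears on the reason for this step.

On these data alone, whether a group of another kind at this position, such as an amine or a carboxylic acid, would give a step beyond the scatter from compound 4 remains open. Also open, as far as these compounds go, is whether hydrogen in place of the other chloro group of compound 2 would give a step of similar size, and whether exchanging both chloro groups together would stay within the scatter.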